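This account rests on a few compounds, and the source may have more. Where it says the series, first, only, none or still open, it means among the compounds named here.

Values so far in a functional assay (aorta) for inhibition, with Oryctolagus cuniculus as the target; on this read-out lower numbers stand for stronger inhibition and higher numbers for weaker inhibition

- compound 1 `CCO/C(O)=C1\C(C)=NC(=S)N(C(=O)OC2CCN(Cc3ccccc3)CC2)C1c1ccccc1C(F)(F)F` gives 9 nM
- compound 2 `CC1=C(C(=O)OC(C)C)C(c2ccccc2C(F)(F)F)N(C(=O)OC2CCN(Cc3ccccc3)CC2)C(=O)N1` gives 50 nM

Of these two numbers, compound 2 stands highest, and its gap to compound 1 lies beyond the scatter, so compound 2 is the weaker inhibitor. The two differ in more than one place, so their gap says nothing about any single group.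

Compound 3 `CC1=C(C(=O)OC(C)C)C(c2ccccc2[N+](=O)[O-])N(C(=O)OC2CCN(Cc3ccccc3)CC2)C(=O)N1` has not yet been measured. It has nitro in place of trifluoromethyl on an aromatic carbon, ortho to a large group (nitro in place of trifluoromethyl on an aromatic carbon). Within the data shown here, no measured compound carries nitro, so the expectation rests on compound 2 at 50 nM. No shift beyond the scatter is expected in this assay, and the expected step is a 1.3-fold lower number from compound 2 to compound 3 (0.10 log units; within the scatter). For compound 3 the estimated value is 40 nM, with an expected range of 12 nM to 130 nM.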

Compound 3, half-maximal inhibitory concentration: 8 nM
Estimate against measurement, compound 3: 5.0-fold (0.70 log units) above; measured number outside the range, below it.
By their numbers in this assay, from the lowest: compounds 3 and 1 (each within the scatter of the next); then compound 2.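

On this aromatic carbon, ortho to a large group, the choice of substituent registers in this assay: nitro in place of trifluoromethyl gives a 6.3-fold lower number from compound 2 to compound 3 (0.80 log units; beyond the scatter). Among these compounds, this is the first comparison that isolates a single place, as the gap between compound 1 and compound 2 could not be assigned to any one group. The compounds shown offer no measurement that would explain the step.

Still open, on these data alone, is whether the same exchange would carry over to the core of compound 1, as nitro appears here on one background only. Also open, as far as these compounds go, is how a nitrile, a chlorine or a methoxy group would read on this carbon, and whether nitro would give a similar value on another carbon of the ring.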